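Bromo to ethoxy on the pendant phenyl ring

A few compounds are considered here, and "the series" means these few. Any claim that something is new, unique, unknown or untested is made for them only; others in the source may bear on it.

Of the compounds shown here, three that share one core have been tested in a functional assay on A549 cells (Homo sapiens) for antiproliferative activity, read by MTT assay, with a stated time of 48 h; a higher number here means a weaker inhibitor, a lower number a stronger inhibitor. Compound 1 `N#CC1=C(N)Oc2c(c3nc4ccccc4nc3c3ccccc23)C12C(=O)N(Cc1cnnn1-c1ccc(Cl)cc1)c1ccccc12` gives only a limit, > 50000 nM. Compound 3 `COc1ccccc1-n1nncc1CN1C(=O)C2(C(C#N)=C(N)Oc3c2c2nc4ccccc4nc2c2ccccc32)c2ccccc21` likewise gives only a limit, > 50000 nM. Among the compounds with values here, compound 2 `N#CC1=C(N)Oc2c(c3nc4ccccc4nc3c3ccccc23)C12C(=O)N(Cc1cnnn1-c1ccc(Br)cc1)c1ccccc12` gives the sole real number, 44300 nM. The step of an at least 1.1-fold lower number from compound 1 to compound 2 (0.05 log units; that floor lies within the scatter) and the step of an at least 1.1-fold higher number from compound 2 to compound 3 (0.05 log units; that floor lies within the scatter) both stay within the scatter, and the step that the two limits leave unreadable from compound 1 to compound 3 cannot be read because both of its ends sit at the limit of > 50000 nM in this assay, at which 2 of the 3 values shown sit. Compound 4 `CCOc1ccc(-n2nncc2CN2C(=O)C3(C(C#N)=C(N)Oc4c3c3nc5ccccc5nc3c3ccccc43)c3ccccc32)cc1` differs from compound 2 by ethoxy in place of bromo on an aromatic carbon. Within the data shown here, none of the measured steps points to a gain, so for compound 4 the expected step is a 1.2-fold higher number from compound 2 to compound 4 (0.09 log units; within the scatter). The estimate for compound 4 in this assay is 55000 nM, within 25000 nM to 150000 nM.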

Compound 4, half-maximal inhibitory concentration: 25200 nM
The estimate for compound 4 lay 2.2-fold (0.34 log units) above the measured number, and the stated range covers the measured number.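

Within the data shown here, compound 4 supplies a second real number, so a step between two measured numbers can be read for the first time: a 1.8-fold lower number from compound 2 to compound 4 (0.25 log units; within the scatter). This means that replacing the bromo with the larger ethoxy at this position does not move activity beyond the scatter. The other two comparisons give only floors, an at least 1.9-fold lower number from compound 3 to compound 4 (0.29 log units; that floor lies within the scatter) and an at least 1.9-fold lower number from compound 1 to compound 4 (0.29 log units; that floor lies within the scatter), and compounds 1 and 3 each carry a limit rather than a number: the limit of > 50000 nM in this assay, at which 2 of the 4 values shown sit.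

On these data alone, whether an amine, a carboxylic acid or a chain longer than ethoxy at this position would move the number beyond the scatter remains open.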